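The compounds below may be only part of what the source reports. "The series", "measured", "known", "first", "only" and "open" are said of these compounds alone.

The compounds measured so far, with their values in an assay on isolated protein for inhibition of histone deacetylase 8 (Homo sapiens), read by fluorescence, with a stated time of 20 min; on this read-out lower numbers stand for stronger inhibition and higher numbers for weaker inhibition:

compound 1, `Nc1ccccc1NC(=O)c1ccc(CNCc2nc(-c3ccc(F)cc3)no2)cc1`: > 10000 nM
compound 2, `O=C(NO)c1ccc(CNCc2nc(-c3ccc(Cl)cc3)no2)cc1`: 350 nM
compound 3, `O=C(NO)c1ccc(CNCc2nc(-c3ccc([N+](=O)[O-])cc3)no2)cc1`: 380 nM

The value for compound 1 in this assay is a limit of the assay, not a number (the limit of > 10000 nM in this assay, at which 1 of the 3 values shown sits). Among the two numbers, compound 3 gives the higher one, yet its neighbour compound 2 sits within the scatter of it: from compound 2 to compound 3 the change is a 1.1-fold higher number from compound 2 to compound 3 (0.04 log units; within the scatter). Compound 4, `O=C(NO)c1ccc(CNCc2nc(-c3ccc(F)cc3)no2)cc1`, has not yet been measured in this assay. It differs from compound 3 in one place: fluoro in place of nitro on an aromatic carbon. Among the measured compounds shown here, the one measured step on that same aromatic carbon, a 1.1-fold higher number from compound 2 to compound 3 (0.04 log units; within the scatter), exchanged chloro for nitro and stayed within the scatter, so the exchange of nitro for fluoro is expected to leave this assay largely unchanged as well. Compound 4 is therefore estimated at 370 nM, within a range from 150 nM to 900 nM. The step this estimate implies is a 1.0-fold lower number from compound 3 to compound 4 (0.01 log units; within the scatter), expected to stay within the scatter.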

Compound 4, half-maximal inhibitory concentration: 230 nM
Compound 4: middle estimate off by 1.6-fold (0.21 log units), on the high side; measured number inside the range.
By their numbers in this assay, from the lowest: compounds 4, 2 and 3 (each within the scatter of the next). At a limit, above all of these: compound 1.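

In this assay, fluoro, with 1 heavy atom, takes the place of nitro, with 3 heavy atoms, on this aromatic carbon and the number stays within the scatter (a 1.7-fold lower number from compound 3 to compound 4 (0.22 log units; within the scatter)), as it also does against chloro (a 1.5-fold lower number from compound 2 to compound 4 (0.18 log units; within the scatter)). Among the compounds shown here, compound 4 also gives the first comparison in one place on the amide-type nitrogen, where hydroxy in place of 2-aminophenyl brings a large step (an at least 43-fold lower number from compound 1 to compound 4 (1.63 log units; beyond the scatter)). Compound 1 gives a limit, not a number: the limit of > 10000 nM in this assay, at which 1 of the 4 values shown sits.

The compounds shown leave open whether an amine, a carboxylic acid or a methoxy group on this same aromatic carbon would also stay within the scatter. They also leave open whether a group other than hydroxy or 2-aminophenyl on the amide-type nitrogen would keep a number like that of compound 4.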